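The compounds below may be only part of what the source reports. "The series", "measured", "known", "first", "only" and "open" are said of these compounds alone.

Measured compounds:
- compound 1 `O=C(Nc1ccc(OC(F)(F)F)cc1)NC1CCN(C(=O)[C@@H]2CCOC2)CC1`: 23 ug/mL
- compound 2 `O=C(Nc1ccc(C(F)(F)F)c(F)c1)NC1CCN(C(=O)C2(C(F)(F)F)CC2)CC1`: 0.08 ug/mL
- compound 3 `O=C(Nc1ccc(OC(F)(F)F)c(F)c1)NC1CCN(C(=O)[C@@H]2CCOC2)CC1`: 61 ug/mL

In a physicochemical assay for solubility, read by mass spectrometry, in phosphate buffer, with a stated time of 24 h, at pH 7.4 (on this read-out lower numbers stand for lower solubility and higher numbers for higher solubility), compound 1 gives 23 ug/mL, the second highest of the three numbers. Among the measured compounds shown here, the nearest measured neighbour is reached by a 2.7-fold higher number from compound 1 to compound 3 (0.42 log units; beyond the scatter), the only single-point step in the set; compound 2 sits far lower, at 0.08 ug/mL, with several changes at once and no step recorded.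

Compound 4 `O=C(Nc1ccc(OC(F)(F)F)cc1)NC1CCN(C(=O)C2CCOC2)CC1` differs from compound 1 only in this: the two compounds have the same atoms and bonds; at least one stereo element is drawn with a configuration in one of them and without one in the other: 1 of 1 stereo elements differ; a stereocentre at a saturated ring carbon is drawn R in compound 1 and without a configuration in compound 4. For the measured compounds named here, no measured step involves a change of this kind, and the atoms and bonds are identical, so the expectation is no step beyond the scatter, no change at the digits printed from compound 1 to compound 4 (within the scatter). Compound 4 is therefore estimated at 23 ug/mL, within a range of 11 ug/mL to 48 ug/mL.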

Compound 4, solubility: 29 ug/mL
Compound 4: middle estimate off by 1.3-fold (0.10 log units), on the low side, and the stated range covers the measured number.
By their numbers in this assay, from the lowest: compound 2; then compounds 1 and 4 (each within the scatter of the next); then compound 3.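

In this assay, among the compounds shown here, the result is a 1.3-fold higher number from compound 1 to compound 4 (0.10 log units; within the scatter), the first step that stays within the scatter. The pair isolates a single feature at this saturated ring carbon: the fact that one of compounds 1 and 4 is drawn with a defined configuration and the other without, at the place where they differ. Dropping the drawn R configuration therefore gives no read-out separable from compound 1 in this assay.

The compounds shown leave open how a compound drawn with the opposite configuration at this carbon would read. They also leave open what an amine or a carboxylic acid on this ring would do to the number.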